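Moving From Compound 2 to Compound 3: An Expected Rise

This account rests on a few compounds, and the source may have more. Where it says the series, first, only, none or still open, it means among the compounds named here.

Compound 2 `CCCC(Oc1ccc(-n2cccn2)cc1)c1ccc(C(=O)NCCC(=O)O)cc1` gives 1.7 in a physicochemical assay for lipophilicity, using the shake flask method, at pH 7.4 (on this read-out lower numbers stand for lower lipophilicity and higher numbers for higher lipophilicity), the lowest of the two numbers measured, while compound 1 `CCCC(Oc1ccc(-n2cc(Cl)cn2)cc1)c1ccc(C(=O)NCCC(=O)O)cc1` stands at 2.6. The change to compound 3 `CCCC(Oc1ccc(-n2cc(C(F)(F)F)c(C)n2)cc1)c1ccc(C(=O)NCCC(=O)O)cc1` is 3-methyl-4-(trifluoromethyl)-1H-pyrazol-1-yl in place of 1H-pyrazol-1-yl on an aromatic carbon. Among the compounds with values here, the one step that bears on it, a number 0.90 log units lower from compound 1 to compound 2 (beyond the scatter), shows that chloro in place of hydrogen alone moves this assay beyond the scatter. The entering group brings a trifluoromethyl and a methyl together, so compound 3 is expected to rise by a number 1.60 log units higher from compound 2 to compound 3 (beyond the scatter), a larger step than that seen before. Compound 3 is therefore estimated at 3.3, within 2.6 to 4.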

Compound 3, distribution coefficient: 2.8
The estimate for compound 3 lay 0.50 log units above the measured number, within the range that was stated.
By their numbers in this assay, from the lowest: compound 2; then compounds 1 and 3 (each within the scatter of the next).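

On an aromatic carbon para to a large group, in this assay, 3-methyl-4-(trifluoromethyl)-1H-pyrazol-1-yl in place of 1H-pyrazol-1-yl gives a number 1.10 log units higher from compound 2 to compound 3 (beyond the scatter) and thus a large step for this double change. Against the chloro group, the same position gives a number 0.20 log units higher from compound 1 to compound 3 (within the scatter) and so does not separate 3-methyl-4-(trifluoromethyl)-1H-pyrazol-1-yl from 4-chloro-1H-pyrazol-1-yl on this read-out. No measured evidence accounts for this result.

Going by these compounds, the methyl and trifluoromethyl enter together, so their separate shares remain open. On these data alone, how a 1H-pyrazol-1-yl carrying an amine or a nitrile would read also remains open.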